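Fluoro to chloro on the compound 3 scaffold

This account rests on a few compounds, and the source may have more. Where it says the series, first, only, none or still open, it means among the compounds named here.

Measured in a functional assay on HeLa cells (Homo sapiens) for inhibition, read by MTT assay, with a stated time of 48 h; a lower number here means a stronger inhibitor of growth, a higher number a weaker inhibitor of growth:
- compound 1 `COc1ccc(C(=O)N2N=C(c3ccccc3)CC2c2cn(C)c3ccccc23)cn1`: 3980 nM
- compound 2 `COc1ccc2c(c1)c(C1CC(c3ccccc3)=NN1C(=O)c1ccc(OC)nc1)cn2C`: 1100 nM
- compound 3 `COc1ccc2c(c1)c(C1CC(c3ccc(F)cc3)=NN1C(=O)c1ccc(OC)nc1)cn2C`: 410 nM

Compound 3 holds the lowest of the three numbers in this assay. Its nearest neighbour is compound 2, and the gap is a 2.7-fold lower number from compound 2 to compound 3 (0.43 log units; beyond the scatter). Compound 1 lies furthest off, at 3980 nM.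

The next structure is compound 4 `COc1ccc2c(c1)c(C1CC(c3ccc(Cl)cc3)=NN1C(=O)c1ccc(OC)nc1)cn2C`, which has not yet been measured. It differs from compound 3 as follows: chloro in place of fluoro on an aromatic carbon. In words, this is chloro in place of fluoro on an aromatic carbon, para to a large group, or 4-fluorophenyl to 4-chlorophenyl.

Two measured steps are available, and both are modest. The closer one is a 2.7-fold lower number from compound 2 to compound 3 (0.43 log units; beyond the scatter), a change at this same carbon. The other, a 3.6-fold lower number from compound 1 to compound 2 (0.56 log units; beyond the scatter), was made elsewhere in the molecule and bears on this question only as a guide to typical step size. Among the compounds with values here, no measured step exchanges one halogen for another, so the direction cannot be read from the data. No step beyond the scatter is expected, and a modest move either way remains possible. The expected change is a 1.1-fold lower number from compound 3 to compound 4 (0.03 log units; within the scatter). For compound 4 the estimated value is 380 nM, with an expected range of 150 nM to 950 nM.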

Compound 4, concentration for 50% growth inhibition: 2260 nM
Beside the measured number, compound 4's estimate is 5.9-fold (0.77 log units) below it; the whole stated range lies below it.
By their numbers in this assay, from the lowest: compound 3; then compound 2; then compounds 4 and 1 (each within the scatter of the next).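

In this assay the para carbon of the phenyl ring proves sensitive to which halogen it carries: the exchange of 4-fluorophenyl for 4-chlorophenyl gives a 5.5-fold higher number from compound 3 to compound 4 (0.74 log units; beyond the scatter) and thereby removes the gain that fluoro had brought, which was a 2.7-fold lower number from compound 2 to compound 3 (0.43 log units; beyond the scatter) at the same carbon. Chloro in place of hydrogen gives a 2.1-fold higher number from compound 2 to compound 4 (0.31 log units; beyond the scatter) and so runs opposite to fluoro, which means that the two halogens fall on either side of the hydrogen compound and that a halogen at this carbon does not by itself lower the number. Nothing available here accounts for this split between fluoro and chloro.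

With only hydrogen, fluoro and chloro at this carbon, no trend across substituents can be drawn, and bromo, methyl, trifluoromethyl, nitrile or an amine could each fall anywhere relative to compound 3. As far as these compounds go, it also remains open whether the order of fluoro and chloro holds on the core of compound 1, which lacks the indole-side methoxy group, and whether it holds in any cell line other than the one used here.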